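Swapping cyclobutyl for cyclopropyl at the ring nitrogen

A few compounds are considered here, and "the series" means these few. Any claim that something is new, unique, unknown or untested is made for them only; others in the source may bear on it.

Of the compounds shown here, three share one core and have been tested in an assay for binding affinity to Corticotropin releasing factor receptor (Rattus norvegicus); a lower number here means a stronger inhibitor, a higher number a weaker inhibitor. Compound 1, `CCc1nc2c(-c3ccc(Cl)cc3Cl)ccnc2n1C(CCOC)C1CC1`, gives 1.5 nM. Compound 2, `CCc1nc2c(-c3ccc(Cl)cc3Cl)ccnc2n1C(CCOC)C1CCC1`, gives 2.4 nM. Compound 3, `CCc1nc2c(-c3ccc(Cl)cc3Cl)ccnc2n1C(C)C1CCC1`, gives 1 nM, the lowest of the three numbers: the gap to compound 1 lies within the scatter, while the gap to compound 2, a 2.4-fold lower number from compound 2 to compound 3 (0.38 log units; beyond the scatter), is beyond it.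

Compound 4, `CCc1nc2c(-c3ccc(Cl)cc3Cl)ccnc2n1[C@H](C)C1CC1`, has not yet been measured. It differs from compound 3 in one place: 1-cyclopropylethyl in place of 1-cyclobutylethyl on an aromatic nitrogen. Within the data shown here, one measured step bears directly on this change, in the opposite direction: a 1.6-fold higher number from compound 1 to compound 2 (0.20 log units; within the scatter), which lay within the scatter. Read backwards, it suggests that returning to cyclopropyl gives, at most, a small move toward a lower number, and perhaps nothing beyond the scatter. Compound 4 is therefore expected to sit close to compound 3, with an estimated step of a 1.4-fold lower number from compound 3 to compound 4 (0.15 log units; within the scatter). The estimate for compound 4 in this assay is 0.7 nM, within a range of 0.35 nM to 1.5 nM.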

Compound 4, inhibition constant: 0.6 nM
Beside the measured number, compound 4's estimate is 1.2-fold (0.07 log units) above it; the measured number falls inside the stated range.
By their numbers in this assay, from the lowest: compounds 4, 3, 1 and 2 (each within the scatter of the next, the first and the last beyond it).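

In this assay, putting 1-cyclopropylethyl in place of 1-cyclobutylethyl on the aromatic nitrogen gives a small step (a 1.7-fold lower number from compound 3 to compound 4 (0.22 log units; within the scatter)), so the ring swap stays within the scatter both with and without the methoxymethyl group. With the cyclopropyl ring kept, losing the methoxymethyl group gives a step beyond the scatter (a 2.5-fold lower number from compound 1 to compound 4 (0.40 log units; beyond the scatter)), so the shorter side chain now goes with a lower number on either ring among these compounds. Making both changes at once gives the largest step in the set, still a modest one (a 4.0-fold lower number from compound 2 to compound 4 (0.60 log units; beyond the scatter)), and nothing available here explains any of these shifts.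

On these data alone, compound 4 is the only one drawn with a defined stereocentre, so how its mirror-image form would compare remains open. Also open, as far as these compounds go, is whether 1-cyclopentylethyl, or an amine on the side chain, would keep the number this low.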